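Rebalancing the chain and the cyanoguanidine in compound 4

This account rests on a few compounds, and the source may have more. Where it says the series, first, only, none or still open, it means among the compounds named here.

Three compounds were tested in a functional assay on the whole organism with Rattus norvegicus as the target, at a dose of 100 mg/kg; a lower number here means less inhibition, a higher number more inhibition at the dose given (going by the name of the read-out). Compound 1 `CC/N=C(/NC#N)NCCCCn1nc(-c2ccccc2)ccc1=O` gives 58.8% and compound 2 `C/N=C(/NC#N)NCCCCCn1nc(-c2ccccc2)ccc1=O` gives 47.6%, so that a number 11.2 percentage points lower from compound 1 to compound 2 (beyond the scatter). Compound 3 `C/N=C(/NC#N)NCCCCCn1nc(-c2ccccc2)c(C)cc1=O` gives 28.5% and stands lowest of the three, with a number 19.1 percentage points lower from compound 2 to compound 3 (beyond the scatter) as the nearer step. The unmeasured compound 4 `CC/N=C(/NC#N)NCCCCn1nc(-c2ccccc2)c(C)cc1=O` differs from compound 3 by a group of 8 heavy atoms (4 carbon, 4 nitrogen; no ring) in place of a group of 8 heavy atoms (4 carbon, 4 nitrogen; no ring), on a saturated chain carbon, four bonds along the chain from an aromatic nitrogen. This is the same exchange as between compound 1 and compound 2, run in the opposite direction, and it leaves the methyl on the aromatic carbon of compound 3 in place. Among the compounds with values here, only the step from compound 1 to compound 2 speaks to this change, and it was modest and beyond the scatter; the step from compound 2 to compound 3 concerns a different position and does not bear on it. Reversing that one step, compound 4 is expected to rise by a number 11.5 percentage points higher from compound 3 to compound 4 (beyond the scatter) in this assay. Compound 4 is therefore estimated at 40%, within a range from 25% to 55%.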

Compound 4, a percentage reported as inhibition, in the whole organism at one dose (the size of the read-out at that dose, not a potency): 38.8%
The estimate for compound 4 lay 1.2 percentage points above the measured number; the measured number falls inside the stated range.
By their numbers in this assay, from the lowest: compound 3; then compounds 4 and 2 (each within the scatter of the next); then compound 1.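

In this assay, the exchange of one group of 8 heavy atoms for the other, on a saturated chain carbon, four bonds along the chain from an aromatic nitrogen, now has a reading on the core that carries the methyl, a number 10.3 percentage points higher from compound 3 to compound 4 (beyond the scatter). The size of this step carries over from the core without the methyl: the same change on two cores in this assay, a number 11.2 percentage points lower (beyond the scatter) from compound 1 to compound 2 and a number 10.3 percentage points lower (beyond the scatter) from compound 4 to compound 3, 0.9 percentage points apart, within the scatter of two such steps Methyl in place of hydrogen on an aromatic carbon also has a second reading, a number 20 percentage points lower from compound 1 to compound 4 (beyond the scatter), and across these four compounds, with none going against it, each change keeps its size whichever form the other takes: the same change on two cores in this assay, a number 19.1 percentage points lower (beyond the scatter) from compound 2 to compound 3 and a number 20 percentage points lower (beyond the scatter) from compound 1 to compound 4, 0.9 percentage points apart, within the scatter of two such steps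

The exchange alters the chain and the end of the cyanoguanidine together, and these compounds do not separate the two. Also open, from the compounds shown here alone, is how a longer chain, or a chlorine in place of the methyl on the aromatic carbon, would read in this assay.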